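The compounds below may be only part of what the source reports. "The series", "measured", "known", "first", "only" and "open" are said of these compounds alone.

Three compounds share one core and differ only in the group attached to the carbonyl carbon: compound 1 `O=C(/C=C/c1ccc2c(c1)B(O)OC2)c1ccco1`, compound 2 `O=C(/C=C/c1ccc2c(c1)B(O)OC2)c1cccnc1` and compound 3 `O=C(/C=C/c1ccc2c(c1)B(O)OC2)c1ccc(Br)cc1`. In a functional assay on MDA-MB-231 cells (Homo sapiens) for cytotoxicity, read by MTT assay, with a stated time of 48 h (on this read-out lower numbers stand for stronger inhibition and higher numbers for weaker inhibition), compound 1 gives 7300 nM, compound 2 gives 11400 nM and compound 3 gives 9500 nM, so compound 3 stands second highest of the three, within the scatter of both neighbours, as the steps of a 1.6-fold higher number from compound 1 to compound 2 (0.19 log units; within the scatter), a 1.3-fold higher number from compound 1 to compound 3 (0.11 log units; within the scatter) and a 1.2-fold lower number from compound 2 to compound 3 (0.08 log units; within the scatter) show. Compound 4 `O=C(/C=C/c1ccc2c(c1)B(O)OC2)c1ccc(C(F)(F)F)cc1` differs from compound 3 by trifluoromethyl in place of bromo on an aromatic carbon. Going by the values given here, no measured step swaps one substituent on that ring for another; every measured swap of the whole carbonyl group stayed within the scatter, so a step within the scatter is expected here too, a 1.1-fold lower number from compound 3 to compound 4 (0.02 log units; within the scatter). Compound 4 is therefore estimated at 9000 nM, between 4000 nM and 20000 nM.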

Compound 4, half-maximal inhibitory concentration: 9200 nM
Compound 4: middle estimate off by 1.0-fold (0.01 log units), on the low side, within the range that was stated.
By their numbers in this assay, from the lowest: compounds 1, 4, 3 and 2 (each within the scatter of the next).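

In this assay, trifluoromethyl in place of bromo gives a 1.0-fold lower number from compound 3 to compound 4 (0.01 log units; within the scatter). Going by these compounds alone, this is the first step that touches only a substituent on the aromatic ring, not the whole group on the carbonyl, and at this place, para to a large group, 4 heavy atoms stand in for 1 without the step leaving the scatter. Nothing measured here explains this result.

From the compounds shown here alone, both groups count 0 hydrogen-bond donors and 0 hydrogen-bond acceptors, so what an amine or a carboxylic acid would do at that place remains open. Going by these compounds, whether a longer chain there would stay within the scatter is equally open.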